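A few compounds are considered here, and "the series" means these few. Any claim that something is new, unique, unknown or untested is made for them only; others in the source may bear on it.

Measured compounds:
- Compound 1 `CCOC(=O)c1cc(-c2cc(OC)c(OC)c(OC)c2)c(-c2ccc(OC)c([N+](=O)[O-])c2)s1`: in a functional assay on KB cells (Homo sapiens) for antiproliferative activity, read by MTT assay, with a stated time of 72 h (on this read-out higher numbers stand for weaker inhibition and lower numbers for stronger inhibition), compound 1 gives 15800 nM.
- Compound 2 `CCOC(=O)c1cc(-c2cc(OC)c(OC)c(OC)c2)c(-c2ccc(OC)c(OCc3ccccc3)c2)s1`: in this assay compound 2 gives only a limit, > 100000 nM.
- Compound 3 `CCOC(=O)c1cc(-c2ccc(OC)c([N+](=O)[O-])c2)c(-c2cc(OC)c(OC)c(OC)c2)s1`: in this assay compound 3 gives 24000 nM.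

Compound 1 and compound 3 carry the same atoms joined differently; the difference between the two cores is not broken down here. Their numbers sit within the scatter of each other. From compound 1 to compound 2 the change is benzyloxy in place of nitro on an aromatic carbon, and this gave an at least 6.3-fold higher number from compound 1 to compound 2 (0.80 log units; beyond the scatter), the number resting at the limit of > 100000 nM in this assay, at which 1 of the 3 values shown sits.

Compound 4 `CCOC(=O)c1cc(-c2ccc(OC)c(OCc3ccccc3)c2)c(-c2cc(OC)c(OC)c(OC)c2)s1` is not yet measured. It arises from compound 3 by benzyloxy in place of nitro on an aromatic carbon, the same change as that from compound 1 to compound 2, with the same surroundings word for word. The step from compound 3 to compound 4 in this assay is therefore expected to be about a 6.3-fold higher number from compound 3 to compound 4 (0.80 log units; beyond the scatter), resting on compound 1 and compound 2 and their step of an at least 6.3-fold higher number from compound 1 to compound 2 (0.80 log units; beyond the scatter). Compound 4 is estimated at 150000 nM, with a fair chance that only a limit is reported.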

Compound 4, half-maximal inhibitory concentration: > 100000 nM
Compound 4: only a limit was reported (the forecaster's own chance of this, stated with the estimate: 70%); the middle value is on the limit's open side.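

In this assay, benzyloxy in place of nitro on an aromatic carbon gives an at least 4.1-fold higher number from compound 3 to compound 4 (0.61 log units; beyond the scatter), so the direction seen on the core of compound 1 holds on the core of compound 3. This shows that weaker inhibition carries over between these two cores, but not that the size of the step does: the same change on two cores in this assay, an at least 6.3-fold higher number (0.80 log units; beyond the scatter) from compound 1 to compound 2 and an at least 4.1-fold higher number (0.61 log units; beyond the scatter) from compound 3 to compound 4; the limit leaves it open whether they differ Compound 2 and compound 4 both give only a limit, so neither step has a measured end point: the limit of > 100000 nM in this assay, at which 2 of the 4 values shown sit.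

As far as these compounds go, whether an amine or a hydroxyl in place of nitro would keep the level of compound 1 and compound 3 stays open. Equally open, from the compounds shown here alone, is how a carboxylic acid or an amide in place of the ethyl ester would read on either core.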